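The source may hold more compounds than are shown below. What is called first, only, known or untested is meant among the compounds shown, and "the series" means these compounds.

Among the measured compounds shown here, compound 1 `Cc1cccc2nc(N3CCN(C)CC3)oc12` gives 5.48 in a functional assay on ileum (strain Hartley) for agonist activity at 5-hydroxytryptamine receptor 3A (Cavia porcellus) (a lower number here means a less potent compound, a higher number a more potent compound, by a factor of ten per unit of this negative logarithm), the only numerical value among the compounds described here. Compound 2 `CCOC(=O)c1ccc2oc(N3CCN(C)CC3)nc2c1` is reported in this assay only as a limit, < 4, which is the limit of < 4 in this assay, at which 1 of the 2 values shown sits. For the measured compounds named here, no step between two measured compounds is therefore available for comparison. Compound 3 `Cc1cc(C)c2oc(N3CCN(C)CC3)nc2c1` differs from compound 1 by methyl in place of hydrogen on an aromatic carbon. Going by the values given here, with no comparable measured step to lean on, the step is expected to be small, within the usual scatter and in no particular direction, a number 0.02 log units higher from compound 1 to compound 3 (within the scatter). Compound 3 is accordingly estimated at 5.5, between 4.8 and 6.2.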

Compound 3, negative logarithm of the half-maximal effective concentration: 6.32
Compound 3: the middle estimate sits 0.82 log units below what was measured; measured number outside the range, above it.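

In this assay, among the compounds shown here, the change of methyl in place of hydrogen on an aromatic carbon, para to a fused ring and meta to a methyl group, gives a number 0.84 log units higher from compound 1 to compound 3 (beyond the scatter) and so provides the first readable step between two measured compounds. It shows that this position of the shared core is not indifferent to substitution, since a single methyl moves the number beyond the scatter. Nothing shown here accounts for the rise.

This rests on one step at one position. The compounds shown leave open whether a longer chain such as ethyl, a halogen such as chlorine, or an amine at this position would move the number in the same direction.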